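The source may hold more compounds than are shown below. What is called first, only, known or untested is meant among the compounds shown, and "the series" means these compounds.

Compound 3 `Cc1ccc(N2C(=O)C/C(=C\c3cccc(C(=O)Nc4ccc(Cl)cc4)c3)C2=O)cc1` was tested in an ADME assay on NCM460 cells (Homo sapiens) for cytotoxicity, read by MTT assay, with a stated time of 72 h; on this read-out higher numbers stand for weaker inhibition and lower numbers for stronger inhibition. In this assay compound 3 reaches only the upper limit, > 100000 nM, which is a boundary of the measurement and not a number. Compound 1 `Cc1ccc(N2C(=O)C/C(=C\c3cccc(C(=O)Nc4cccc(F)c4)c3)C2=O)cc1`, which carries a 3-fluorophenyl on the same amide-type nitrogen, likewise gives only the limit > 100000 nM in this assay. Compound 2 `CCc1cccc(NC(=O)c2cccc(/C=C3\CC(=O)N(Cc4ccccc4)C3=O)c2)c1`, with a 3-ethylphenyl on that nitrogen and a benzyl on the imide nitrogen, also sits at the limit > 100000 nM. Going by the values given here, the one step with a known pair, a step that the two limits leave unreadable from compound 1 to compound 3, cannot be read in size, since both ends sit at the limit (the limit of > 100000 nM in this assay, at which 3 of the 3 values shown sit).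

Compound 4 `CCc1cccc(NC(=O)c2cccc(/C=C3\CC(=O)N(c4ccc(C)cc4)C3=O)c2)c1` differs from compound 3 by 3-ethylphenyl in place of 4-chlorophenyl on an amide-type nitrogen. Among the compounds with values here, every value so far sits at the same limit, so there is no measured step to transfer, and the aryl group that enters is the one compound 2 already carries while sitting at the limit. The expected step that the limit leaves unreadable from compound 3 to compound 4 is therefore none that the scatter would reveal. Compound 4 is estimated at 150000 nM, within 70000 nM to 400000 nM, most likely reported again only as the limit.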

Compound 4, half-maximal inhibitory concentration: > 100000 nM
Compound 4: a limit, no number; the forecaster's own chance of this, stated with the estimate: 85%; the middle value lies beyond the limit too.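

Going by these compounds alone, no step from compound 1, compound 2 or compound 3 to compound 4 can be read in size, since both ends of each pair are limits and not numbers: the limit of > 100000 nM in this assay, at which 4 of the 4 values shown sit. The compounds shown leave open what value any of them would give in this assay, and whether any of these group changes alters it.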